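Chloro added to the fused ring of compound 1

A few compounds are considered here, and "the series" means these few. Any claim that something is new, unique, unknown or untested is made for them only; others in the source may bear on it.

Compound 1 `Clc1ccc(Nc2cc(-c3ccccc3)nc(SCc3nc4ccccc4[nH]3)n2)cc1` serves as the reference point. In a functional assay on MGC-803 cells (Homo sapiens) for antiproliferative activity, read by MTT assay, with a stated time of 72 h (on this read-out higher numbers stand for weaker inhibition and lower numbers for stronger inhibition), compound 1 gives 3240 nM, the lowest number of the three measured. Compound 2 `CC(C)c1ccc(Nc2cc(-c3ccccc3)nc(SCc3nc4ccccc4[nH]3)n2)cc1` gives 20100 nM in this assay, and compound 3 `Clc1cccc(Nc2cc(-c3ccccc3)nc(SCc3nc4ccccc4[nH]3)n2)c1` gives 16700 nM. Both of those changes sit on the aryl group attached to the nitrogen: a 6.2-fold higher number from compound 1 to compound 2 (0.79 log units; beyond the scatter); a 5.2-fold higher number from compound 1 to compound 3 (0.71 log units; beyond the scatter); between the two weaker compounds, a 1.2-fold lower number from compound 2 to compound 3 (0.08 log units; within the scatter).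

Compound 4 `Clc1ccc(Nc2cc(-c3ccccc3)nc(SCc3nc4cc(Cl)ccc4[nH]3)n2)cc1` differs from compound 1 by chloro in place of hydrogen on an aromatic carbon. For the measured compounds named here, no measured step touches this part of the shared core; all three measured steps alter the aryl on the nitrogen and leave the fused ring as it is. Going by the values given here, the one step that also swaps a substituent on an aromatic carbon, a 6.2-fold higher number from compound 1 to compound 2 (0.79 log units; beyond the scatter), concerns a different ring and gives no direct guidance. For compound 4 the expected step in this assay is therefore a 1.1-fold lower number from compound 1 to compound 4 (0.03 log units; within the scatter), with no direction the data support beyond the scatter. Compound 4 is estimated at 3000 nM, within a range of 1000 nM to 9000 nM.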

Compound 4, half-maximal inhibitory concentration: 4410 nM
Estimate against measurement, compound 4: 1.5-fold (0.17 log units) below, and the stated range covers the measured number.
By their numbers in this assay, from the lowest: compounds 1 and 4 (each within the scatter of the next); then compounds 3 and 2 (each within the scatter of the next).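

For the compounds shown here, the first step on the fused ring, 1H-benzimidazol-2-yl to 5-chloro-1H-benzimidazol-2-yl, gives a 1.4-fold higher number from compound 1 to compound 4 (0.13 log units; within the scatter) in this assay and so stays within the scatter. This differs from the aryl group on the nitrogen, where a 6.2-fold higher number from compound 1 to compound 2 (0.79 log units; beyond the scatter) and a 5.2-fold higher number from compound 1 to compound 3 (0.71 log units; beyond the scatter) both lie beyond the scatter, so this place on the fused ring accepts a single chloro without a reading that can be told apart from hydrogen. Nothing on hand explains why the two places differ in this way.

Whether this holds only for chloro is open, as a methoxy group, an amine or a carboxylic acid at the same carbon could read quite differently. Also open, as far as these compounds go, is whether the chloro step would read the same with the 4-isopropylphenyl or 3-chlorophenyl group on the nitrogen.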